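The source may hold more compounds than are shown below. What is called first, only, known or untested is meant among the compounds shown, and "the series" means these compounds.

Compound 1 `C[C@]1(O)C[C@](c2cccc(OC(F)(F)F)c2)([C@H](O)c2ccccn2)C1`: 117 mL/min/kg
Compound 2 `O[C@H](c1ccccn1)[C@]1(c2cccc(OC(F)(F)F)c2)C[C@H](O)C1`: 150 mL/min/kg

Both numbers come from an ADME assay on liver for metabolic stability, with Liver microsome (Homo sapiens) as the target, read by LC-MS, using microsomes, with a stated time of 5 h; a lower number here means slower removal, a higher number faster removal of the compound. For the measured compounds named here, compound 1, at 117 mL/min/kg, stands within the scatter of compound 2, the only other compound measured so far. Compound 3 `C[C@]1(O)C[C@](c2cccc(C(F)(F)F)c2)([C@H](O)c2ccccn2)C1` keeps the core of compound 1 and changes one group: trifluoromethyl in place of trifluoromethoxy on an aromatic carbon. Going by the values given here, the single measured step, a 1.3-fold higher number from compound 1 to compound 2 (0.11 log units; within the scatter), is a swap of hydrogen for methyl on a saturated ring carbon, so it stays within the scatter and does not touch the aromatic carbon. Among the compounds with values here, no measured step covers this exchange, so no shift beyond the scatter is expected. The expected change is a 1.1-fold lower number from compound 1 to compound 3 (0.03 log units; within the scatter). Compound 3 is estimated at 110 mL/min/kg, with an expected range of 60 mL/min/kg to 175 mL/min/kg.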

Compound 3, clearance: 33.3 mL/min/kg
Compound 3: middle estimate off by 3.3-fold (0.52 log units), on the high side; measured number below the stated range.
By their numbers in this assay, from the lowest: compound 3; then compounds 1 and 2 (each within the scatter of the next).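

In this assay, for the compounds shown here, the aromatic carbon proves sensitive to what it carries: trifluoromethyl in place of trifluoromethoxy gives a 3.5-fold lower number from compound 1 to compound 3 (0.55 log units; beyond the scatter) and is the first step here to lie beyond the scatter. The exchange removes only one oxygen atom from the group, so a small edit at this position can change how fast the compound is removed. Nothing measured here gives the reason for this shift. Going by these compounds, whether other groups on this aromatic carbon, such as a nitrile or a chlorine atom, would give a lower number remains open. Also open, on these data alone, is whether the same exchange would have a similar effect on compound 2.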